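Swapping a Piperidine Tail for a Fused Bicyclic Amine

The compounds below may be only part of what the source reports. "The series", "measured", "known", "first", "only" and "open" are said of these compounds alone.

Measured so far:
compound 1, `COc1ccc2[nH]c(C(=O)N3CC(=O)N(Cc4ccccc4)[C@@H](CN4CCCCC4)C3)cc2c1`: > 25000 nM
compound 2, `COc1ccc2[nH]c(C(=O)N3CC(=O)N(Cc4cccc(OC(F)F)c4)[C@@H](CN4CCC(C#N)CC4)C3)cc2c1`: 27900 nM
compound 3, `COc1cccc(CN2C(=O)CN(C(=O)c3cc4cc(OC)ccc4[nH]3)C[C@@H]2Cc2ccccn2)c1`: 57900 nM

All three share a core in which an indole carboxamide is tied to a piperazinone ring. Their solubility was measured in a physicochemical assay for solubility, read by spectrophotometry, in phosphate buffer, with a stated time of 2 h, at pH 7.4; on this read-out higher numbers stand for higher solubility and lower numbers for lower solubility. For compound 1 the result is a limit of the assay, not a number: compound 1 shows > 25000 nM, which means the true value lies somewhere past the point the assay could resolve. Compound 2 gives 27900 nM and compound 3 gives 57900 nM, both as full numbers. So compound 1 stands, at minimum, in the same broad region as the other two; how far above it reaches is not known, and since the limit of > 25000 nM in this assay, at which 1 of the 3 values shown sits, applies, nothing finer can be said about its position.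

The unmeasured compound 4 is `COc1ccc2[nH]c(C(=O)N3CC(=O)N(Cc4ccccc4)[C@@H](CN4CC5CC5C4)C3)cc2c1`. It differs from compound 1 in a single place: a group of 6 heavy atoms (5 carbon, 1 nitrogen; one three-membered non-aromatic ring of carbon only, one five-membered non-aromatic ring with 1 hetero atom) in place of a group of 6 heavy atoms (5 carbon, 1 nitrogen; one six-membered non-aromatic ring with 1 hetero atom), on a saturated chain carbon bound to a saturated ring carbon. The basic amine and the count of heavy atoms are unchanged; only the shape of the ring around the nitrogen moves from a single six-membered ring to a fused three- and five-membered pair.

Among the compounds with values here, no measured pair of compounds differing in one place exists here, so there is no directly comparable step. The expectation is that the step from compound 1 to compound 4 in this assay is small, a step that the limit leaves unreadable from compound 1 to compound 4, not beyond the usual scatter. Compound 4 is therefore estimated at 35000 nM, with a range from 15000 nM to 90000 nM.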

Compound 4, solubility: 17500 nM
The estimate for compound 4 lay 2.0-fold (0.30 log units) above the measured number; low and high end bracket the measured number.
By their numbers in this assay, from the lowest: compounds 4 and 2 (each within the scatter of the next); then compound 3.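

In this assay, within the data shown here, the change from the piperidin-1-yl group to the fused three- and five-membered ring pair, on a saturated chain carbon bound to a saturated ring carbon, provides the first comparison between compounds that differ in one place: it gives an at least 1.4-fold lower number from compound 1 to compound 4 (0.15 log units; that floor lies within the scatter) while the counts of heavy atoms, hydrogen-bond donors and hydrogen-bond acceptors stay the same. For compound 1, > 25000 nM is a limit of the assay and not a number. The real size of the step therefore remains unknown, and the change can only be given a floor rather than a fixed value, because one end of the comparison is a limit: the limit of > 25000 nM in this assay, at which 1 of the 4 values shown sits.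

On these data alone, how far compound 1 actually lies past its limit remains open, and with it whether this ring change moves solubility by more than the usual scatter. Also open, as far as these compounds go, is how other amines at this place, such as a morpholine or a pyrrolidine, would read in this assay with the rest of compound 1 kept the same, since compound 2 and compound 3 differ from it in more than one place.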